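Thiophene replacing dichlorophenyl on the shared core

The source may hold more compounds than are shown below. What is called first, only, known or untested is meant among the compounds shown, and "the series" means these compounds.

Three measured compounds share one core with a trifluoromethyl ketone on a thiophene. Compound 1 `Cc1ccc(-c2noc(-c3ccc(C(=O)C(F)(F)F)s3)n2)cc1` gives 110 nM in an assay for inhibition of histone deacetylase 4 (Homo sapiens); on this read-out higher numbers stand for weaker inhibition and lower numbers for stronger inhibition. Compound 2 `O=C(c1ccc(-c2nc(Cc3cccs3)no2)s1)C(F)(F)F` gives 15 nM in this assay, and compound 3 `O=C(c1ccc(-c2nc(-c3ccc(Cl)cc3Cl)no2)s1)C(F)(F)F` gives 240 nM. Compound 3 has the highest number of the three; its nearest neighbour is compound 1, its furthest compound 2, with a 16-fold higher number from compound 2 to compound 3 (1.20 log units; beyond the scatter) and a 2.2-fold higher number from compound 1 to compound 3 (0.34 log units; beyond the scatter).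

Compound 4 `O=C(c1ccc(-c2nc(-c3cccs3)no2)s1)C(F)(F)F` is not yet measured. The change is thiophen-2-yl in place of 2,4-dichlorophenyl on an aromatic carbon. The same position carries 4-methylphenyl in compound 1, (thiophen-2-yl)methyl in compound 2 and 2,4-dichlorophenyl in compound 3.

Among the measured compounds shown here, two measured steps bear on the change. The step of a 16-fold higher number from compound 2 to compound 3 (1.20 log units; beyond the scatter) is large and removes a thiophene ring together with its methylene in favour of 2,4-dichlorophenyl; compound 4 reverses the ring part of that step but keeps the ring directly on the core, as in compound 1 and compound 3. The step of a 7.3-fold lower number from compound 1 to compound 2 (0.87 log units; beyond the scatter) shows that (thiophen-2-yl)methyl gave a modestly lower number than a directly attached six-membered ring.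

A lower number is therefore expected for compound 4 than for compound 3, beyond the scatter, probably short of compound 2, estimated as a 6.0-fold lower number from compound 3 to compound 4 (0.78 log units; beyond the scatter). Compound 4 is expected to give about 40 nM, within 12 nM to 130 nM.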

Compound 4, half-maximal inhibitory concentration: 95 nM
Compound 4: the middle estimate sits 2.4-fold (0.38 log units) below what was measured; the range from low to high includes it.
By their numbers in this assay, from the lowest: compound 2; then compounds 4 and 1 (each within the scatter of the next); then compound 3.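

In this assay, thiophen-2-yl in place of 2,4-dichlorophenyl gives a 2.5-fold lower number from compound 3 to compound 4 (0.40 log units; beyond the scatter), but the ring attached directly to the shared core does not reach compound 2, with a 6.3-fold higher number from compound 2 to compound 4 (0.80 log units; beyond the scatter); the thiophene ring alone therefore does not carry the low number seen with (thiophen-2-yl)methyl. Among the directly attached groups, thiophen-2-yl and 4-methylphenyl cannot be told apart, with a 1.2-fold lower number from compound 1 to compound 4 (0.06 log units; within the scatter), so across these two compounds the change from a six-membered to a five-membered aromatic ring leaves the number within the scatter. No measurement at hand gives a reason for any of these differences.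

A benzyl group at this position would show whether the low number of compound 2 goes with the methylene link or with the thiophene ring it carries, and 2-(thiophen-2-yl)ethyl would extend that comparison to a longer chain. The compounds shown also leave open how an aminomethyl group would behave here, and whether these steps hold with a group other than the trifluoromethyl ketone on the core.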